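The source may hold more compounds than are shown below. What is called first, only, known or untested is meant among the compounds shown, and "the series" means these compounds.

Two oxalamide-type... 

Correction: the piece begins here.

Of the compounds shown here, two sharing one core have been measured so far, compound 1 `C[C@H](NC(=O)C(=O)NCCC1CCCC1)C(=O)N[C@@H](CC(=O)O)C(=O)COc1c(F)c(F)cc(F)c1F` and compound 2 `Cc1ccccc1CNC(=O)C(=O)N[C@@H](C)C(=O)N[C@@H](CC(=O)O)C(=O)COc1c(F)c(F)cc(F)c1F`. In a functional assay on Jurkat cells (Homo sapiens) (a higher number here means a weaker inhibitor, a lower number a stronger inhibitor), compound 1 gives 11 nM, while compound 2 gives 52 nM. Compound 2 therefore holds the higher number of the two, making it the weaker inhibitor of this pair. The step between them, a 4.7-fold higher number from compound 1 to compound 2 (0.67 log units; beyond the scatter), put 2-methylphenyl in place of cyclopentylmethyl and was modest, though beyond the scatter.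

Compound 3 `Cc1ccc(CNC(=O)C(=O)N[C@@H](C)C(=O)N[C@@H](CC(=O)O)C(=O)COc2c(F)c(F)cc(F)c2F)cc1` is the next to consider. It carries 4-methylphenyl in place of 2-methylphenyl on a saturated chain carbon bound to an amide-type nitrogen. The two have the same atoms, joined differently. For the measured compounds named here, the one measured step at this place bears on the change only indirectly, as it exchanged one group for a different kind of group. Going by the values given here, no measurement yet shows what the new arrangement of the methylphenyl group does. A step smaller than that one is therefore expected in this assay, with no direction indicated by the data, and possibly none beyond the scatter. The expected change is a 1.2-fold lower number from compound 2 to compound 3 (0.06 log units; within the scatter). For compound 3 the estimated value is 45 nM, within an expected range of 17 nM to 120 nM.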

Compound 3, half-maximal inhibitory concentration: 50 nM
For compound 3 the middle estimate is 1.1-fold (0.05 log units) below the measured one; low and high end bracket the measured number.
By their numbers in this assay, from the lowest: compound 1; then compounds 3 and 2 (each within the scatter of the next).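

In this assay, 4-methylphenyl in place of 2-methylphenyl on a saturated chain carbon bound to an amide-type nitrogen gives a 1.0-fold lower number from compound 2 to compound 3 (0.02 log units; within the scatter), so the two arrangements of the methylphenyl group cannot be told apart at this place. The gap to compound 1 therefore does not belong to the 2-methylphenyl group alone: 4-methylphenyl in place of cyclopentylmethyl gives a 4.5-fold higher number from compound 1 to compound 3 (0.66 log units; beyond the scatter), in the same direction as the earlier step, and neither methylphenyl compound goes against this pattern within these three compounds. No measurement at hand accounts for either result.

The compounds shown leave open whether the gap to compound 1 follows the aromatic ring or the methyl group on it, a question that a plain phenyl group or a cyclohexylmethyl group at the same place could help to settle. Also open, going by these compounds, is how this assay would respond to an amine or a carboxylic acid on the ring, or to a longer chain joining the ring to the amide-type nitrogen.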